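The source may hold more compounds than are shown below. What is called first, only, known or untested is meant among the compounds shown, and "the series" means these compounds.

Of the compounds shown here, three built on one shared core have been tested in an ADME assay on V79 cells (Cricetulus griseus) for cytotoxicity, read by MTT assay, with a stated time of 72 h; a lower number here means a stronger inhibitor, a higher number a weaker inhibitor. Compound 1 `COc1ccc(Nc2nnnn2-c2ccc(Br)cc2)cc1` gives 125000 nM, and compound 3 `COc1ccc(Nc2nnnn2-c2cccc(Cl)c2)cc1` gives 124000 nM; the change between them, 3-chlorophenyl in place of 4-bromophenyl on an aromatic nitrogen, gave a 1.0-fold lower number from compound 1 to compound 3 (0.00 log units; within the scatter). Compound 2 `COc1ccc(-n2nnnc2Nc2ccccc2Cl)cc1` gives 246000 nM. Its number is nominally the highest of the three, but its gaps to compound 1 and to compound 3 both fall within the scatter, so the three cannot be told apart on these data.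

Compound 4 `COc1ccc(-n2nnnc2Nc2ccccc2F)cc1` differs from compound 2 in a single place: fluoro in place of chloro on an aromatic carbon. Among the compounds with values here, no measured step swaps one halogen for another on this ring, so there is nothing that bears directly on the change. Within the data shown here, the only halogen swap seen, from compound 1 to compound 3, stayed within the scatter. On that slender basis, compound 4 is expected to show a step of a 1.1-fold lower number from compound 2 to compound 4 (0.05 log units; within the scatter) in this assay, that is, nothing beyond the scatter. The estimate for compound 4 is therefore 220000 nM, with a range from 90000 nM to 500000 nM.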

Compound 4, half-maximal inhibitory concentration: 115000 nM
The estimate for compound 4 lay 1.9-fold (0.28 log units) above the measured number, within the range that was stated.
By their numbers in this assay, from the lowest: compounds 4, 3, 1 and 2 (each within the scatter of the next, the first and the last beyond it).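

Within the data shown here, the change from chloro to fluoro on an aromatic carbon, ortho to a large group, brought a 2.1-fold lower number from compound 2 to compound 4 (0.33 log units; beyond the scatter) in this assay and so gives the first step here to pass the usual scatter, though only modestly. The earlier step from compound 1 to compound 3 changed both the halogen and the aromatic ring's substitution and stayed within the scatter, whereas this one changes only the halogen at a single place, and the number responds. No measured information explains why the swap has this effect. On these data alone, it remains open whether the response extends beyond halogens, for example to an amine or a carboxylic acid at this place. It is also unknown whether the same chloro-to-fluoro swap would give a similar step elsewhere on the shared core.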